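The compounds below may be only part of what the source reports. "The series", "measured", "known", "first", "only" and "open" are said of these compounds alone.

Measured so far:
compound 1, `CC(C)(O)[C@@H](Nc1nc(Cl)nc2c1ccn2[C@H]1[C@H](O)[C@H](O)[C@]2(CO)C[C@H]12)C1CC1`: 63000 nM
compound 2, `OC[C@@]12C[C@@H]1[C@@H](n1ccc3c(NC(C4CCC4)C4CCC4)nc(Cl)nc31)[C@H](O)[C@@H]2O`: 86000 nM
compound 3, `OC[C@@]12C[C@@H]1[C@@H](n1cnc3c(NC(C4CCC4)C4CCC4)nc(Cl)nc31)[C@H](O)[C@@H]2O`: 28000 nM

All three were tested in an ADME assay on Vero 76 cells (Chlorocebus sabaeus) for cytotoxicity, read by neutral red uptake; on this read-out higher numbers stand for lower toxicity in this test and lower numbers for higher toxicity in this test. Compound 2 and compound 1 share a core and differ in one place: 1-cyclopropyl-2-hydroxy-2-methylpropyl in place of dicyclobutylmethyl on a nitrogen on an aromatic ring. That change made a 1.4-fold lower number from compound 2 to compound 1 (0.14 log units; within the scatter). Compound 3 carries a different core from compound 2, and how the two cores differ is not broken down here; in this assay compound 3 gives 28000 nM, the lowest of the three numbers.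

Compound 4, `CC(C)(O)[C@@H](Nc1nc(Cl)nc2c1ncn2[C@H]1[C@H](O)[C@H](O)[C@]2(CO)C[C@H]12)C1CC1`, has not been measured yet. It stands to compound 3 as compound 1 stands to compound 2, the change being (1-cyclopropyl-2-hydroxy-2-methylpropyl in place of dicyclobutylmethyl on a nitrogen on an aromatic ring). Because the same change gave a 1.4-fold lower number from compound 2 to compound 1 (0.14 log units; within the scatter) on the other core, a step of similar size, a 1.3-fold lower number from compound 3 to compound 4 (0.10 log units; within the scatter), is expected here. Compound 4 is therefore estimated at 22000 nM, with a likely range from 10000 nM to 50000 nM.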

Compound 4, half-maximal cytotoxic concentration: > 100000 nM
Compound 4: a limit, no number; the forecaster's own chance of this, stated with the estimate: 5%; middle value at least 4.5-fold (0.65 log units) away from the limit.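

In this assay compound 4 gives > 100000 nM and this is a limit of the assay, not a number. The new step, an at least 3.5-fold higher number from compound 3 to compound 4 (0.55 log units; beyond the scatter), is a smallest size and not an exact one. The change did not carry over in the same way from one core to the other, although two cores give no general rule and no reason for the gap: the same change on two cores in this assay, a 1.4-fold lower number (0.14 log units; within the scatter) from compound 2 to compound 1 and an at least 3.5-fold higher number (0.55 log units; beyond the scatter) from compound 3 to compound 4, at least 4.8-fold (0.68 log units) apart, beyond the scatter of two such steps.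

The compounds shown leave open how large the step on the core of compound 3 really is. They also leave open whether the same gap between cores appears with other groups on that nitrogen, such as a plain cyclopropylmethyl or a chain ending in an amine.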